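Triazole-aryl variation on the tosylated core, cytotoxicity

The compounds below may be only part of what the source reports. "The series", "measured", "known", "first", "only" and "open" are said of these compounds alone.

Measured compounds:
compound 1 `C=C1C(=O)[C@]23C[C@@]1(O)CC[C@H]2c1ccc(OS(=O)(=O)c2ccc(C)cc2)c(C)c1[C@@H]3Cn1cc(-c2ccc(Br)cc2)nn1`: 4320 nM
compound 2 `C=C1C(=O)[C@]23C[C@@]1(O)CC[C@H]2c1ccc(O)c(C)c1[C@@H]3Cn1cc(-c2ccccn2)nn1`: 1270 nM
compound 3 `C=C1C(=O)[C@]23C[C@@]1(O)CC[C@H]2c1ccc(OS(=O)(=O)c2ccc(C)cc2)c(C)c1[C@@H]3Cn1cc(-c2ccc(OC)cc2)nn1`: 1720 nM

All three were run in a functional assay on SMMC-7721 cells (Homo sapiens) for cytotoxicity, read by MTT assay, with a stated time of 4 days; a higher number here means a weaker inhibitor, a lower number a stronger inhibitor. Compound 3 holds the second highest number of the three in this assay; compound 2 lies closest to it, within the scatter, and compound 1 furthest, beyond it. Going by the values given here, the only step measured at the aryl group on the triazole is a 2.5-fold lower number from compound 1 to compound 3 (0.40 log units; beyond the scatter), a modest move.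

Compound 4 `C=C1C(=O)[C@]23C[C@@]1(O)CC[C@H]2c1ccc(OS(=O)(=O)c2ccc(C)cc2)c(C)c1[C@@H]3Cn1cc(-c2ccccn2)nn1` differs from compound 3 in one place: pyridin-2-yl in place of 4-methoxyphenyl on an aromatic carbon. Among the compounds with values here, the same position is the one touched by the step from compound 1 to compound 3, so that step is the nearest guide, and it was modest. Compound 2 also bears pyridin-2-yl but differs from compound 4 elsewhere, so its value gives only loose support. A step in this assay of no more than modest size is therefore expected, in no firm direction, and most likely within the scatter: a 1.1-fold lower number from compound 3 to compound 4 (0.06 log units; within the scatter). Compound 4 is estimated at 1500 nM, range 600 nM to 4000 nM.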

Compound 4, half-maximal inhibitory concentration: 2830 nM
Compound 4: middle estimate off by 1.9-fold (0.28 log units), on the low side, and the stated range covers the measured number.
By their numbers in this assay, from the lowest: compounds 2, 3, 4 and 1 (each within the scatter of the next, the first and the last beyond it).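

In this assay pyridin-2-yl in place of 4-methoxyphenyl gives a 1.6-fold higher number from compound 3 to compound 4 (0.22 log units; within the scatter) and pyridin-2-yl in place of 4-bromophenyl gives a 1.5-fold lower number from compound 1 to compound 4 (0.18 log units; within the scatter) at this carbon of the five-membered aromatic ring. The pyridin-2-yl compound therefore cannot be ordered against either aryl compound, although those two are separated by a step beyond the scatter. Going by these compounds alone, with pyridin-2-yl held fixed, (4-methylphenyl)sulfonyl in place of hydrogen on the oxygen gives a 2.2-fold higher number from compound 2 to compound 4 (0.35 log units; beyond the scatter) and is the only new step beyond the scatter, a first sign that this oxygen also affects the number. No data at hand explain any of these steps.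

Going by these compounds, the effect of an amine or a carboxylic acid on the aryl group at this position remains open. Also open, on these data alone, is whether the change on the oxygen gives a similar step with 4-methoxyphenyl or 4-bromophenyl in place.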